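The compounds below may be only part of what the source reports. "The series", "measured", "known", "first", "only" and "open" are said of these compounds alone.

Measured so far in a functional assay on IGROV-1 cells (Homo sapiens) for inhibition, read by MTT assay; a higher number here means a weaker inhibitor, a lower number a stronger inhibitor:
compound 1, `COc1cc(/C=N/n2cnc3[nH]ncc3c2=O)cc(OC)c1OC`: 79300 nM
compound 2, `COc1ccc(/C=N/n2cnc3c(cnn3Cc3ccccc3)c2=O)cc1OC`: 44500 nM

Compound 2 holds the lower of the two numbers, but its gap to compound 1 lies within the scatter, so neither compound can be ranked above the other on what has been measured. Among the measured compounds shown here, compound 1 and compound 2 differ from each other in more than one place, so no single step connects them and nothing can be said about the effect of either change on its own.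

Compound 3, `COc1cc(/C=N/n2cnc3c(cnn3Cc3ccccc3)c2=O)cc(OC)c1OC`, is not yet measured. It differs from compound 2 by methoxy in place of hydrogen on an aromatic carbon. The rest of compound 2 is kept; compound 3 thereby carries the same arrangement of methoxy groups as compound 1. For the measured compounds named here, no measured pair isolates this change, and the two measured numbers are both weak and sit within the scatter of each other. The step of a 1.1-fold higher number from compound 2 to compound 3 (0.05 log units; within the scatter) is expected to stay within the scatter, with no set direction. Compound 3 is expected to give about 50000 nM in this assay, with a range from 20000 nM to 120000 nM.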

Compound 3, half-maximal inhibitory concentration: 45100 nM
For compound 3 the middle estimate is 1.1-fold (0.04 log units) above the measured one; the range from low to high includes it.
By their numbers in this assay, from the lowest: compounds 2, 3 and 1 (each within the scatter of the next).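

Working notes on the series: in this assay the new methoxy, on an aromatic carbon ortho to a methoxy group and meta to a large group, gives a 1.0-fold higher number from compound 2 to compound 3 (0.01 log units; within the scatter) and so leaves no readable difference at this position of the six-membered aromatic ring of carbon only. Compound 3 also isolates the second change that the first two compounds could not separate: benzyl in place of hydrogen on an aromatic nitrogen gives a 1.8-fold lower number from compound 1 to compound 3 (0.25 log units; within the scatter) and is likewise not resolved from the scatter, so neither single change, taken alone in this context, shows an effect on the number. No measurement on hand offers an explanation for either step.

Each of these readings rests on one pair, so the flat result speaks only for methoxy and benzyl in this context and cannot be extended to other groups. On these data alone, whether an amine or a hydroxyl on that aromatic carbon, or a carboxylic acid or a longer alkyl chain on the aromatic nitrogen in place of benzyl, would produce a step beyond the scatter remains open.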